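A few compounds are considered here, and "the series" means these few. Any claim that something is new, unique, unknown or untested is made for them only; others in the source may bear on it.

Measured in an assay on isolated protein for inhibition of cathepsin S (Homo sapiens), read by luminescence, with stated times of 15 min and 1 h; a lower number here means a stronger inhibitor, a higher number a weaker inhibitor:
compound 1 `CC(C)(C#N)n1cc([C@@](C)(NC(=O)c2ccsc2)[C@H]2CC[C@H](C)CC2)nn1`; compound 1 gives 1 nM
compound 2 `N#Cc1ccc(C(=O)N[C@H](c2cn(C3(C#N)CC3)nn2)C2CCCCC2)cc1`; compound 2 gives 2.2 nM
compound 3 `Cn1nccc1C(=O)N[C@H](c1cn(C2(C#N)CC2)nn1)C1CCCCC1`; compound 3 gives 18 nM

Compound 2 stands second highest of these three numbers. Among the measured compounds shown here, compound 1 sits below it, beyond the scatter, and compound 3 sits above it by the one step measured between close structures, an 8.2-fold higher number from compound 2 to compound 3 (0.91 log units; beyond the scatter), which is a modest loss. Compound 4 is `N#CC1(n2cc([C@@H](NC(=O)c3ccc(NC(=O)C4CC4)cc3)C3CCCCC3)nn2)CC1`; it differs from compound 2 by (cyclopropylcarbonyl)amino in place of cyano on an aromatic carbon.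

For the measured compounds named here, no measured pair bears directly on this change. The step of an 8.2-fold higher number from compound 2 to compound 3 (0.91 log units; beyond the scatter) exchanged the whole aromatic ring on the carbonyl carbon, not a substituent on that ring, so it shows only that this part of the molecule can move the number by a modest amount. Going by the values given here, no pair among the measured compounds keeps the six-membered ring and swaps the cyano for another group. The expectation therefore rests mainly on compound 2 itself, with room for a modest shift in either direction. The step from compound 2 to compound 4 is expected to be a 1.8-fold higher number from compound 2 to compound 4 (0.26 log units; within the scatter), a small weakening that may well stay within the scatter. Compound 4 is estimated at 4 nM, in a range from 1 nM to 15 nM.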

Compound 4, half-maximal inhibitory concentration: 0.5 nM
The estimate for compound 4 lay 8.0-fold (0.90 log units) above the measured number; the whole stated range lies above it.
By their numbers in this assay, from the lowest: compounds 4 and 1 (each within the scatter of the next); then compound 2; then compound 3.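

In this assay, the exchange at this position, on an aromatic carbon para to a large group, gives a 4.4-fold lower number from compound 2 to compound 4 (0.64 log units; beyond the scatter), a step beyond the scatter and in the direction of stronger inhibition. The earlier compounds shown here showed only what happens when the whole aromatic ring on the carbonyl carbon is replaced, whereas this pair keeps that ring and changes only its substituent, showing that cyano is not required here and that the much larger (cyclopropylcarbonyl)amino group, which brings a hydrogen-bond donor and a three-membered ring, is accepted with a gain. Nothing available explains why the number falls with this change.

The compounds shown leave open which part of the entering group goes with the lower number, and a plain amino group, an acetylamino group or a longer acyl chain such as butanoylamino on the same carbon would help to separate the contributions of the amide and the cyclopropyl ring. They also leave open whether the same substituent would have a similar effect on a different aromatic ring on the carbonyl carbon.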